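Methyl on the ring of compound 2: expected effect

The compounds below may be only part of what the source reports. "The series", "measured", "known", "first", "only" and "open" are said of these compounds alone.

Measured so far in a functional assay on A-431 cells (Homo sapiens) for cytotoxicity, read by MTT assay, with a stated time of 72 h, tested at 30 uM; a lower number here means less inhibition of growth, a higher number more inhibition of growth at the concentration tested:
compound 1 `Cc1cccc(/C(N)=N/NC(=S)N2CCN(c3ccccn3)CC2)n1`: 57.4%
compound 2 `N/C(=N\NC(=S)N1CCOCC1)c1ccccn1`: 78.8%
compound 3 `N/C(=N\NC(=S)N1CCN(c2ccccn2)CC1)c1ccc(F)cn1`: 62.3%

Compound 2 stands highest of the three in this assay; compound 3 is nearest and compound 1 furthest, and both gaps from compound 2 lie beyond the scatter. Compound 4 `Cc1ccnc(/C(N)=N/NC(=S)N2CCOCC2)c1` is not yet measured. It differs from compound 2 by methyl in place of hydrogen on an aromatic carbon, meta to a large group and opposite the ring nitrogen.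

Among the compounds with values here, the only measured step that touches the same six-membered aromatic ring is the one from compound 1 to compound 3, where 5-fluoropyridin-2-yl replaces 6-methylpyridin-2-yl: a number 4.9 percentage points higher from compound 1 to compound 3 (within the scatter). A swap of substituents on that ring thus left the read-out essentially unchanged, though the two compounds carry a different amine than compound 2 and the substituent sits elsewhere on the ring, so the bearing is indirect.

On this basis the step of a number 3.8 percentage points lower from compound 2 to compound 4 (within the scatter) is expected to stay within the scatter. For compound 4 the estimate in this assay is 75%, with a likely range from 60% to 88%.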

Compound 4, percent growth inhibition at one concentration: 74.6%
Compound 4: middle estimate off by 0.4 percentage points, on the high side; low and high end bracket the measured number.
By their numbers in this assay, from the lowest: compounds 1 and 3 (each within the scatter of the next); then compounds 4 and 2 (each within the scatter of the next).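

In this assay, methyl in place of hydrogen on an aromatic carbon, meta to a large group and opposite the ring nitrogen, gives a number 4.2 percentage points lower from compound 2 to compound 4 (within the scatter), so this change leaves the read-out unmoved at this position. Unlike the earlier step on this ring, this one keeps the amine of compound 2 and changes a single place, which makes it a direct reading of the position. No measured property bears on this result.

On these data alone, whether a longer chain such as ethyl, an amine or a carboxylic acid on the same aromatic carbon would also leave the read-out in place remains open. Also open, as far as these compounds go, is whether methyl at this position would give a similar result with the piperazine-type amine of compound 1 and compound 3, since only the amine of compound 2 is covered here.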